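Methyl in Place of Chloro on the Core of Compound 2

The source may hold more compounds than are shown below. What is called first, only, known or untested is meant among the compounds shown, and "the series" means these compounds.

Compound 1, `Cc1cc(Nc2nc(NCc3ccc(F)cc3F)nc3ccccc23)n[nH]1`, gives 200 nM in an assay for inhibition of high affinity nerve growth factor receptor (Homo sapiens), read by HTRF, with a stated time of 30 min, in the presence of a further agent that is not named here; a lower number here means a stronger inhibitor, a higher number a weaker inhibitor.
Compound 2, `Cc1cc(Nc2nc(NCc3ccc(F)cc3F)nc3cc(Cl)ccc23)n[nH]1`, gives 15 nM in this assay.
Compound 3, `Fc1ccc(CNc2nc(Nc3cc(C4CC4)[nH]n3)c3ccc(Cl)cc3n2)c(F)c1`, gives 290 nM in this assay.

Compound 2 holds the lowest number of the three. Its nearest neighbour is compound 1, reached by a 13-fold lower number from compound 1 to compound 2 (1.12 log units; beyond the scatter), and its furthest is compound 3, reached by a 19-fold higher number from compound 2 to compound 3 (1.29 log units; beyond the scatter); both steps lie beyond the scatter.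

Compound 4, `Cc1ccc2c(Nc3cc(C)[nH]n3)nc(NCc3ccc(F)cc3F)nc2c1`, has not yet been measured. It differs from compound 2 by methyl in place of chloro on an aromatic carbon. Going by the values given here, the step that bears on this change is the one from compound 1 to compound 2, where chloro replaced hydrogen at the same position on the fused ring and gave the large step already noted. Among the compounds with values here, no measured pair shows methyl at this position, so the data say nothing directly about how methyl compares with chloro or with hydrogen there. Since methyl is neither of the two groups already tried, compound 4 is expected to land between compound 1 and compound 2, with a step of a 3.3-fold higher number from compound 2 to compound 4 (0.52 log units; beyond the scatter) expected toward a higher number. Compound 4 is therefore estimated at 50 nM, within a range of 15 nM to 200 nM.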

Compound 4, half-maximal inhibitory concentration: 27 nM
Compound 4: the middle estimate sits 1.9-fold (0.27 log units) above what was measured; low and high end bracket the measured number.
By their numbers in this assay, from the lowest: compounds 2 and 4 (each within the scatter of the next); then compounds 1 and 3 (each within the scatter of the next).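

Methyl in place of hydrogen on this aromatic carbon gives a 7.4-fold lower number from compound 1 to compound 4 (0.87 log units; beyond the scatter) in this assay and so lies beyond the scatter, which shows that the earlier step of a 13-fold lower number from compound 1 to compound 2 (1.12 log units; beyond the scatter) is not a finding about chloro alone. Methyl in place of chloro gives a 1.8-fold higher number from compound 2 to compound 4 (0.26 log units; within the scatter) and stays within the scatter, so at this position the two groups cannot be told apart in this measurement, although one brings a carbon and the other a chlorine. Nothing given here bears on why either group differs from hydrogen or why the two read alike.

The compounds shown leave open whether a methoxy group, an amine or a carboxylic acid on this same carbon would stay within the scatter of compound 2 or fall back toward the number of compound 1. They also leave open whether the step of a 19-fold higher number from compound 2 to compound 3 (1.29 log units; beyond the scatter), seen with chloro on the core, would be repeated if cyclopropyl replaced the methyl on the other ring of compound 4 .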